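The compounds below may be only part of what the source reports. "The series", "measured", "known", "first", "only" and "open" are said of these compounds alone.

Measured so far in a functional assay on HeLa cells (Homo sapiens) for cytotoxicity, read by WST assay, with a stated time of 48 h; a lower number here means a stronger inhibitor, a higher number a weaker inhibitor:
- compound 1 `CCCCCC/C=C/C[C@H]1C[C@@H]([C@@H](O)c2ccccc2)CO[C@@H]1c1ccccc1`: 7400 nM
- compound 2 `COc1ccc([C@@H]2OC[C@H]([C@@H](O)c3ccc(OC)c(OC)c3)C[C@H]2C/C=C/c2ccc(OC)c(OC)c2)cc1`: 29200 nM

Among the measured compounds shown here, compound 1 stands at the lowest of the two numbers so far; compound 2 sits at a higher number, and the gap between the two is beyond the usual scatter, so compound 1 is the stronger inhibitor of the pair on present evidence. For the measured compounds named here, no step between measured compounds that differ in a single place is available, so nothing is yet known about how the series responds to any one change.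

Compound 3 `O[C@@H](c1ccccc1)[C@H]1CO[C@H](c2ccccc2)[C@@H](C/C=C/C2CCCCC2)C1` is not yet measured. Its change from compound 1 is cyclohexyl in place of hexyl on a double-bonded chain carbon bound to a double-bonded chain carbon. The part that leaves and the part that enters carry the same count of heavy atoms, with no donors, acceptors or charge on either side; the change turns an open chain into a saturated ring at the same place on the chain.

With no measured step of this kind in the series, the expectation is for a step from compound 1 to compound 3 of a 1.2-fold higher number from compound 1 to compound 3 (0.09 log units; within the scatter) in this assay, small and well within the scatter, with a lean toward a slightly higher number. Compound 3 is estimated at 9000 nM, in a range from 3500 nM to 25000 nM.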

Compound 3, half-maximal inhibitory concentration: 6440 nM
Estimate against measurement, compound 3: 1.4-fold (0.15 log units) above; the range from low to high includes it.
By their numbers in this assay, from the lowest: compounds 3 and 1 (each within the scatter of the next); then compound 2.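

In this assay the series now has its first step that differs in one place, a 1.1-fold lower number from compound 1 to compound 3 (0.06 log units; within the scatter), and it lies within the scatter, so compound 1 and compound 3 cannot be told apart. At this place, on a double-bonded chain carbon bound to a double-bonded chain carbon, cyclohexyl and hexyl are therefore interchangeable in this pair: closing the open chain into a saturated ring of the same heavy-atom count leaves no measurable trace in this read-out. No measurement at hand bears on why the two compounds match.

Going by these compounds, what remains open is whether this place accepts groups of a different kind, such as an amine, a carboxylic acid, a phenyl ring or a longer chain such as decyl, or whether the flat response holds only for groups of carbon alone and of this size. A single pair also cannot show whether the equivalence of hexyl and cyclohexyl carries over when other parts of the core of compound 1 are changed.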